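The source may report more compounds than this note shows. Statements on the series, on what has been measured and on what is new or still open speak of the compounds shown alone.

Measured compounds in an assay on microsomes from liver for inhibition of 3-hydroxy-3-methylglutaryl-coenzyme A reductase (Rattus norvegicus); on this read-out lower numbers stand for stronger inhibition and higher numbers for weaker inhibition:
Compound 1 `CC(C)c1c(C(=O)N2CCCC2c2ccccc2)nn(-c2ccc(F)cc2)c1OC[C@@H](O)C[C@@H](O)CC(=O)O`: compound 1 gives 14 nM.
Compound 2 `CC(C)c1c(C(=O)NCc2cccc(Cl)c2)nn(-c2ccc(F)cc2)c1OC[C@@H](O)C[C@@H](O)CC(=O)O`: compound 2 gives 5.4 nM.
Compound 3 `COc1cc(CN(C)C(=O)c2nn(-c3ccc(F)cc3)c(OC[C@@H](O)C[C@@H](O)CC(=O)O)c2C(C)C)cc(OC)c1`: compound 3 gives 43 nM.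

Compound 3 stands at the highest number of the three. Among the compounds with values here, compound 1 sits lower, beyond the scatter, and compound 2 lower still, also beyond the scatter; no single-point step is defined between compound 3 and either of them, so only the values themselves are compared here.

Within the data shown here, the one measured step lies at the amide: a 2.6-fold lower number from compound 1 to compound 2 (0.41 log units; beyond the scatter). It shows that changes of the amide substituent move this read-out by a modest amount in this series.

Compound 4 `CC(C)c1c(C(=O)N(C)[C@H](C)c2ccccc2)nn(-c2ccc(F)cc2)c1OC[C@@H](O)C[C@@H](O)CC(=O)O` differs from compound 3 by 1-phenylethyl in place of 3,5-dimethoxybenzyl on an amide-type nitrogen. Among the measured compounds shown here, no measured step matches this change exactly. The nearest point of comparison is compound 1, which also carries a tertiary amide with a phenyl-bearing substituent and gives 14 nM, a lower number than compound 3. The amide step a 2.6-fold lower number from compound 1 to compound 2 (0.41 log units; beyond the scatter) suggests a change of roughly this size is plausible, direction uncertain but leaning toward lower numbers, with compound 1 as the anchor.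

The step is expected as a 2.2-fold lower number from compound 3 to compound 4 (0.33 log units; beyond the scatter). Compound 4 is estimated at 20 nM, within a range of 7 nM to 60 nM.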

Compound 4, half-maximal inhibitory concentration: 21 nM
The estimate for compound 4 lay 1.1-fold (0.02 log units) below the measured number; low and high end bracket the measured number.
By their numbers in this assay, from the lowest: compound 2; then compounds 1 and 4 (each within the scatter of the next); then compound 3.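

In this assay, the group on the amide-type nitrogen matters even among the tertiary amides: 1-phenylethyl in place of 3,5-dimethoxybenzyl gives a 2.0-fold lower number from compound 3 to compound 4 (0.31 log units; beyond the scatter), although the methoxy groups leave and a defined stereocentre enters in the same change, so the step cannot be assigned to either feature alone. The step of a 1.5-fold higher number from compound 1 to compound 4 (0.18 log units; within the scatter) lies within the scatter, so the methyl(1-phenylethyl)amino and 2-phenylpyrrolidin-1-yl amides cannot be told apart on this read-out despite their different amine parts. The step of a 3.9-fold higher number from compound 2 to compound 4 (0.59 log units; beyond the scatter) is beyond the scatter, which leaves the (3-chlorobenzyl)amino amide at the lower number of this pair, but the change also replaces the chlorine-bearing benzyl group and the amide hydrogen, so it does not isolate any single feature.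

No measured evidence accounts for any of these differences. Still open, from the compounds shown here alone, are how the opposite configuration of 1-phenylethyl would read in this assay and how a benzyl group carrying an amine or a carboxylic acid would fare on the same amide-type nitrogen.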